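The source may hold more compounds than are shown below. What is called first, only, known or untested is meant among the compounds shown, and "the series" means these compounds.

Within the data shown here, compound 1 `N#Cc1ccc(C(=O)Nc2cccc(NC(=O)COc3ccc4c(=O)ccoc4c3)c2)cc1` gives 15 nM in an assay on isolated protein for inhibition of Rho-associated protein kinase 2 (Homo sapiens), read by scintillation counting, radiometric assay and 33P incorporation, with a stated time of 40 min, in the presence of a further agent that is not named here (a higher number here means a weaker inhibitor, a lower number a stronger inhibitor), the lower of the two numbers measured so far. Compound 2 `CN(C)c1ccc(S(=O)(=O)Nc2cccc(NC(=O)COc3ccc4c(=O)ccoc4c3)c2)cc1` gives 263 nM in this assay, a clearly weaker result. Compound 3 `NCc1ccc(C(=O)Nc2cccc(NC(=O)COc3ccc4c(=O)ccoc4c3)c2)cc1` has not yet been measured; it differs from compound 1 in a single place: aminomethyl in place of cyano on an aromatic carbon. Among the measured compounds shown here, no measured pair shows this exact change, so the expectation rests on compound 1 alone: a small step toward a weaker inhibitor, near the edge of the scatter, is expected, a 2.7-fold higher number from compound 1 to compound 3 (0.43 log units; beyond the scatter). Compound 3 is therefore estimated at 40 nM, within a range from 8 nM to 200 nM.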

Compound 3, half-maximal inhibitory concentration: 66 nM
Estimate against measurement, compound 3: 1.7-fold (0.22 log units) below, and the stated range covers the measured number.
By their numbers in this assay, from the lowest: compound 1; then compound 3; then compound 2.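

In this assay, putting aminomethyl in place of cyano on the aromatic carbon para to a large group gives a 4.4-fold higher number from compound 1 to compound 3 (0.64 log units; beyond the scatter). So this position responds to the group it carries, though the loss is modest, and compound 3, with its hydrogen-bond donor here, still gives 66 nM. No measurement at hand explains this step.

From the compounds shown here alone, whether a plain amine on the ring, an aminoethyl chain or a carboxylic acid at this position would come closer to compound 1 stays open. So does whether the same change would have a similar effect on compound 2.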